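Swapping a hydroxymethylene link for a vinyl link

The compounds below may be only part of what the source reports. "The series", "measured", "known", "first", "only" and "open" are said of these compounds alone.

Two compounds share an ethylsulfonyl amide core bearing a pyridinylmethyl arm, and differ in where a phenyl-bearing carbon is attached to the central aromatic ring. Compound 1, with structure `CCS(=O)(=O)N(Cc1cccnc1)c1ccc(C(O)c2ccccc2)cc1`, was tested in an assay on isolated protein with metabotropic glutamate receptor 2 (Homo sapiens) as the target; on this read-out higher numbers stand for an effect only at larger amounts of compound and lower numbers for an effect already at smaller amounts. In this assay compound 1 gives > 30000 nM, which is a limit of the assay rather than a number, as stated in the limit of > 30000 nM in this assay, at which 1 of the 2 values shown sits. For the measured compounds named here, compound 2, with structure `CCS(=O)(=O)N(Cc1cccnc1)c1cccc(C(O)c2ccccc2)c1`, is the only compound of the pair with a measured number: in this assay compound 2 gives 2500 nM.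

The next compound builds on compound 2. Compound 3, with structure `C=C(c1ccccc1)c1cccc(N(Cc2cccnc2)S(=O)(=O)CC)c1`, differs in one place: 1-phenylethenyl in place of hydroxy(phenyl)methyl on an aromatic carbon. The hydroxyl group of compound 2 is thereby removed and a double bond takes its place, so compound 3 carries no hydrogen-bond donor at this position.

Going by the values given here, no measured pair here shows what such a swap does. The expectation for compound 3 therefore rests on compound 2 alone, which in this assay gives 2500 nM. The step of a 1.2-fold higher number from compound 2 to compound 3 (0.08 log units; within the scatter) is estimated to stay within the usual scatter. For compound 3 the estimated value in this assay is 3000 nM, expected to lie between 1000 nM and 10000 nM.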

Compound 3, half-maximal effective concentration: 200 nM
For compound 3 the middle estimate is 15-fold (1.18 log units) above the measured one, outside the stated range (below it).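

Putting 1-phenylethenyl in place of hydroxy(phenyl)methyl on this aromatic carbon gives a 13-fold lower number from compound 2 to compound 3 (1.10 log units; beyond the scatter) in this assay, and on this read-out a lower number means an effect already at smaller amounts of compound. The hydroxyl group of compound 2 is therefore not needed for activity at this position: compound 3 has no hydrogen-bond donor or acceptor in the entering group, yet it acts at smaller amounts, so this position responds strongly to a change that leaves the phenyl ring in place. Nothing measured here explains the size of this change, so the result stands as an observation without a known cause.

The swap removes the hydroxyl group and adds the double bond in a single step, so a plain methylene link, a carbonyl link or a methoxy group on the same carbon would be needed to separate the two changes. On these data alone, it also remains open whether 1-phenylethenyl would have a similar effect at the ring position used in compound 1, which gives > 30000 nM, a limit of the assay and not a number.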